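From Compound 1 to Compound 4: An Added Amino Group

This account rests on a few compounds, and the source may have more. Where it says the series, first, only, none or still open, it means among the compounds named here.

In a functional assay on K562 cells (Homo sapiens), read by MTT assay, with a stated time of 72 h (a higher number here means a weaker inhibitor, a lower number a stronger inhibitor), compound 1 `C#Cc1cn([C@@H]2O[C@H](CO)[C@@H](O)[C@H]2O)c2ncnc(OC)c12` gives 380 nM, which places it at the upper end of the measured numbers, level within the scatter with compound 2 `C#Cc1cn([C@@H]2O[C@H](CO)[C@@H](O)[C@H]2O)c2ncnc(N(C)C)c12` at 260 nM. Dimethylamino in place of methoxy on an aromatic carbon gives a 1.5-fold lower number from compound 1 to compound 2 (0.16 log units; within the scatter). Compound 3 `C#Cc1cn([C@@H]2O[C@H](CO)[C@@H](O)[C@H]2O)c2ncnc(C)c12`, at 110 nM, stands clear of both. Methyl in place of methoxy gives a 3.5-fold lower number from compound 1 to compound 3 (0.54 log units; beyond the scatter), and methyl in place of dimethylamino gives a 2.4-fold lower number from compound 2 to compound 3 (0.37 log units; beyond the scatter).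

Compound 4 `C#Cc1cn([C@@H]2O[C@H](CO)[C@@H](O)[C@H]2O)c2nc(N)nc(OC)c12` keeps the methoxy group of compound 1 and changes a different carbon: amino in place of hydrogen on an aromatic carbon. This is amino in place of hydrogen on an aromatic carbon, between two ring nitrogen atoms. Among the measured compounds shown here, none of the measured steps touches that carbon, so the data offer no direct precedent and no firm direction. They bear on the question only indirectly: the largest change seen elsewhere on the shared core is the modest 3.5-fold lower number from compound 1 to compound 3 (0.54 log units; beyond the scatter). A step beyond the scatter is therefore not expected, although the uncertainty is wide. The expected step is a 1.6-fold higher number from compound 1 to compound 4 (0.20 log units; within the scatter). For compound 4 the estimated value is 600 nM, with an expected range of 120 nM to 3000 nM.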

Compound 4, half-maximal inhibitory concentration: > 20000 nM
Compound 4: a limit, no number; the forecaster's own chance of this, stated with the estimate: 10%; middle value at least 33-fold (1.52 log units) from the limit.
By their numbers in this assay, from the lowest: compound 3; then compounds 2 and 1 (each within the scatter of the next). At a limit, above all of these: compound 4.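

Compound 4 is recorded in this assay only as a limit of the assay, not as a number: the limit of > 20000 nM in this assay, at which 1 of the 4 values shown sits. Amino in place of hydrogen on the aromatic carbon between two ring nitrogen atoms gives an at least 52-fold higher number from compound 1 to compound 4 (1.72 log units; beyond the scatter), the only step shown at this position and the first large one in the series. The earlier compounds shown here varied a different carbon, where the widest step is a 3.5-fold lower number from compound 1 to compound 3 (0.54 log units; beyond the scatter), so they gave no sign that a single added amino group at this second position could carry the methoxy compound so far towards weaker inhibition in K562 cells.

The compounds shown leave open whether this loss belongs to the amino group in particular or to any substituent at this carbon, since no other group, such as fluorine, chlorine, methyl or methylamino, stands there for comparison. They also leave open whether amino at this carbon would have the same outcome with methyl or dimethylamino in place of the methoxy group, and the limit leaves the true size of the step for compound 4 undefined.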